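Hydroxy for methoxy on the aryl amine of compound 2

A few compounds are considered here, and "the series" means these few. Any claim that something is new, unique, unknown or untested is made for them only; others in the source may bear on it.

Compound 1 `O=C1COCCN1c1ccc(Nc2nc(Cl)nc(NC3CCCCC3)n2)cc1` gives 81% in a functional assay on the whole organism (strain Swiss) for inhibition, with Mus musculus as the target, with a stated time of 30 min, at a dose of 10 mg/kg by the intraperitoneal route (a lower number here means a weaker effect, a higher number a stronger effect of the compound at the dose given), and compound 2 `COc1ccc(Nc2nc(Cl)nc(Nc3ccc(N4CCOCC4=O)cc3)n2)cc1` gives 79%. Compound 2 holds the lowest of the two numbers, its nearest neighbour being compound 1, with a number 2 percentage points lower from compound 1 to compound 2 (within the scatter). Compound 3 `O=C1COCCN1c1ccc(Nc2nc(Cl)nc(Nc3ccc(O)cc3)n2)cc1` differs from compound 2 by hydrogen in place of methyl on an oxygen on an aromatic ring. Within the data shown here, no measured step alters this oxygen; the only step, cyclohexyl to 4-methoxyphenyl, stayed within the scatter. A step of a number 3 percentage points lower from compound 2 to compound 3 (within the scatter) is therefore expected, none beyond the scatter. Compound 3 is estimated at 76%, in the range 60% to 90%.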

Compound 3, a percentage reported as inhibition, in the whole organism at one dose (the size of the read-out at that dose, not a potency): 68%
For compound 3 the middle estimate is 8 percentage points above the measured one, within the range that was stated.
By their numbers in this assay, from the lowest: compound 3; then compounds 2 and 1 (each within the scatter of the next).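

In this assay the substituent on this oxygen matters: methoxy to hydroxy gives a number 11 percentage points lower from compound 2 to compound 3 (beyond the scatter), whereas cyclohexyl to 4-methoxyphenyl stayed within the scatter. The 4-hydroxyphenyl group also separates from cyclohexyl, with a number 13 percentage points lower from compound 1 to compound 3 (beyond the scatter), so an aryl group on this nitrogen is tolerated with methoxy but gives a lower number with hydroxy. Nothing available explains this difference. From the compounds shown here alone, it remains open whether a longer chain on this oxygen, such as ethoxy, would hold the number of compound 2, and how an amine in place of the hydroxy would compare.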